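This account rests on a few compounds, and the source may have more. Where it says the series, first, only, none or still open, it means among the compounds named here.

Notes on the series: in a functional assay on SH-SY5Y cells (Homo sapiens) for cytotoxicity, read by MTT assay, with a stated time of 72 h (on this read-out higher numbers stand for weaker inhibition and lower numbers for stronger inhibition), compound 1 `CN(C)CCCCCn1c2c(c3ccccc31)C(=O)c1c[n+]([O-])c3ccccc3c1C2=O` gives 370 nM and compound 2 `O=C1c2c[n+]([O-])c3ccccc3c2C(=O)c2c1c1ccccc1n2Cc1cn([C@H]2O[C@H](CO)[C@@H](O)[C@H]2O)nn1` gives 1340 nM. Compound 3 `O=C1c2c[n+]([O-])c3ccccc3c2C(=O)c2c1c1ccccc1n2Cc1cn(CC(O)CO)nn1` gives > 1000 nM, which is a limit of the assay and not a number. Its standing therefore rests only on (the limit of > 1000 nM in this assay, at which 1 of the 3 values shown sits).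

Compound 4 `O=C1c2c[n+]([O-])c3ccccc3c2C(=O)c2c1c1ccccc1n2CCCCN1CCNCC1` differs from compound 3 as follows: 3-(piperazin-1-yl)propyl in place of 1-(2,3-dihydroxypropyl)-1H-1,2,3-triazol-4-yl on a saturated chain carbon bound to an aromatic nitrogen. In words, 3-(piperazin-1-yl)propyl stands in place of 1-(2,3-dihydroxypropyl)-1H-1,2,3-triazol-4-yl on a saturated chain carbon bound to an aromatic nitrogen.

The closest measured step is an at least 2.7-fold higher number from compound 1 to compound 3 (0.43 log units; beyond the scatter). That step brought the triazole group in where 4-(dimethylamino)butyl had been, whereas the present change removes it again in favour of another amine-bearing chain. The other measured step, a step that the limit leaves unreadable from compound 2 to compound 3, gives no usable size. A step of modest size towards lower numbers is therefore expected in this assay, with compound 1 at 370 nM as the reference. The expected step is an at least 2.2-fold lower number from compound 3 to compound 4 (0.34 log units; beyond the scatter). For compound 4 the estimated value is 450 nM, with an expected range of 150 nM to 1300 nM.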

Compound 4, half-maximal inhibitory concentration: 1240 nM
Compound 4: middle estimate off by 2.8-fold (0.44 log units), on the low side; the measured number falls inside the stated range.
By their numbers in this assay, from the lowest: compound 1; then compounds 4 and 2 (each within the scatter of the next).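

In this assay, piperazin-1-yl in place of (dimethylamino)methyl on a saturated chain carbon, four bonds along the chain from an aromatic nitrogen, gives a 3.4-fold higher number from compound 1 to compound 4 (0.53 log units; beyond the scatter). Among the compounds shown, an amine on the chain is therefore not enough to keep the lower number, and the identity of the amine end group moves the read-out at this position. Compound 3 stands at a limit and not at a number, so the step from it to the new compound cannot be read: the limit of > 1000 nM in this assay, at which 1 of the 4 values shown sits.

As far as these compounds go, it remains open whether the higher number follows the piperazine ring itself or the ring's free nitrogen-hydrogen. A 4-methylpiperazin-1-yl or a morpholin-4-yl group on the same chain would separate these two readings.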